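The source may report more compounds than this note shows. Statements on the series, on what has been measured and on what is new or still open speak of the compounds shown alone.

In an assay for binding affinity to Alpha-1B adrenergic receptor (Homo sapiens) (on this read-out higher numbers stand for weaker inhibition and lower numbers for stronger inhibition), the measured compounds stand as follows:
- compound 2 `O=c1c2ccccc2c(Cc2ccc(Cl)cc2)nn1CCNCCCCc1ccc(OCCCN2CCCCCC2)cc1` gives 316 nM
- compound 3 `O=c1c2ccccc2c(Cc2ccc(Cl)cc2)nn1C1CCCN(Cc2ccc(OCCCN3CCCCCC3)cc2)CC1` gives 126 nM
- compound 1 `COC(=O)c1ccc(Cc2nn(C[C@H]3CCCN3C)c(=O)c3ccccc23)cc1` reaches only a limit of this assay, > 1990 nM

Of the two numbers in hand, compound 2 holds the higher one, and compound 3 sits lower by a gap beyond the usual scatter. Compound 1 adds no number, only a limit.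

Compound 4 `CN(CCCCc1ccc(OCCCN2CCCCCC2)cc1)CCn1nc(Cc2ccc(Cl)cc2)c2ccccc2c1=O` differs from compound 2 in a single place: methyl in place of hydrogen on an amine nitrogen. Within the data shown here, no measured pair shows this kind of change, so the expected step from compound 2 to compound 4 is small, a 1.3-fold lower number from compound 2 to compound 4 (0.10 log units; within the scatter), in no firm direction and not beyond the scatter. Compound 4 is therefore expected to give about 250 nM, with a likely range from 80 nM to 800 nM.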

Compound 4, inhibition constant: > 1990 nM
Compound 4: no number, only a limit; the forecaster's own chance of this, stated with the estimate: 5%; middle value at least 7.9-fold (0.90 log units) from the limit.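

On the amine nitrogen of compound 2, one added methyl is enough to shift the result, with methyl in place of hydrogen giving an at least 6.2-fold higher number from compound 2 to compound 4 (0.79 log units; beyond the scatter). Among these compounds, no earlier pair showed any single change, so this is the first sign that this nitrogen is a sensitive place. In this assay compound 4 gives only a limit, so the step's full size cannot be read: the limit of > 1990 nM in this assay, at which 2 of the 4 values shown sit.

Going by these compounds, whether an ethyl group or a longer chain on this nitrogen would weaken binding to the same degree stays open. So does whether an acetyl group there would.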